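Shifting the aryl group on the amide carbonyl

A few compounds are considered here, and "the series" means these few. Any claim that something is new, unique, unknown or untested is made for them only; others in the source may bear on it.

The compounds here share one core, an aryl amide carrying a bis(trifluoromethyl)phenoxy aniline, and differ only in the ring on the carbonyl carbon. Compound 1 `O=C(Nc1ccc(Oc2cc(C(F)(F)F)cc(C(F)(F)F)c2)cc1)c1cc(Cl)ccc1F` gives 1110 nM in an assay on HEK293 cells for inhibition of Toll-like receptor 8 (Homo sapiens), with a stated time of 16 h; on this read-out higher numbers stand for weaker inhibition and lower numbers for stronger inhibition. Compound 2 `O=C(Nc1ccc(Oc2cc(C(F)(F)F)cc(C(F)(F)F)c2)cc1)c1ccc(I)cc1F` reaches only a limit in this assay, > 50000 nM, so no number is known for it. For the measured compounds named here, the step of an at least 45-fold higher number from compound 1 to compound 2 (1.65 log units; beyond the scatter) is therefore large, and it is the only measured step; it rests on the limit described by the limit of > 50000 nM in this assay, at which 1 of the 3 values shown sits. Compound 3 `O=C(Nc1ccc(Oc2cc(C(F)(F)F)cc(C(F)(F)F)c2)cc1)c1c(F)cccc1C(F)(F)F` has no result in this assay, reported as "not determined" (no result reported), so it cannot be placed among these numbers. Compound 4 `O=C(Nc1ccc(Oc2cc(C(F)(F)F)cc(C(F)(F)F)c2)cc1)c1ccc(O)cc1F` is compound 3 with 2-fluoro-4-hydroxyphenyl in place of 2-fluoro-6-(trifluoromethyl)phenyl on a carbonyl carbon.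

Going by the values given here, no measured step matches this change. Among the compounds with values here, the one step known, from a chlorine to an iodine on the ring that sits on the carbonyl carbon, weakened inhibition strongly, and compound 2, the weak one, carries its iodine in the same 4-position that the hydroxy group of compound 4 occupies. That is a loose hint only, since a hydroxy group is not an iodine and compound 3 itself is unmeasured. With so little to anchor it, compound 4 is expected to fall toward the weaker side, at an estimated 10000 nM, within a wide range from 1500 nM to 50000 nM, and it may well return only a limit.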

Compound 4, half-maximal inhibitory concentration: > 50000 nM
Compound 4 was reported as a limit (the forecaster's own chance of this, stated with the estimate: 35%); at least 5.0-fold (0.69 log units) between middle value and limit.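

For the compounds shown here, replacing the 5-chloro-2-fluorophenyl ring on the carbonyl carbon with 2-fluoro-4-hydroxyphenyl gives an at least 45-fold higher number from compound 1 to compound 4 (1.65 log units; beyond the scatter) in this assay, so iodo is not the only group on this ring that comes with such a loss. The result for compound 4, > 50000 nM, is a limit of the assay, and compound 2 stands at that same limit, so the step between these two cannot be read and neither the hydroxy nor the iodo compound can be ranked above the other. Among the compounds with a result, only compound 1 keeps an actual number, and the others gather at one end of the scale: the limit of > 50000 nM in this assay, at which 2 of the 4 values shown sit.

On these data alone, what stays open is whether the loss follows from the hydroxy and iodo groups themselves or simply from leaving the ring of compound 1, and compound 3 cannot settle this, since it has no number. A methoxy group, an amine or a carboxylic acid in place of the hydroxy group could show whether any compound with this ring returns a measurable value rather than a limit.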